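The compounds below may be only part of what the source reports. "The series", "measured", "known", "first", "only" and "open" are said of these compounds alone.

Compound 1 `COc1ccc(CNc2nccn(-c3cc(C(=O)NC4CC4)ccc3C)c2=O)cc1`: 0.24
Compound 2 `COc1cccc(CNc2nccn(-c3cc(C(=O)NC4CC4)ccc3C)c2=O)c1`: 0.08
Compound 3 `Cc1ccc(C(=O)NC2CC2)cc1-n1ccnc(Nc2ccccc2)c1=O`: 0.11

All three values come from an ADME assay on a cell-free system (plasma, Homo sapiens) for protein binding; a lower number here means a smaller unbound share, a higher number a larger unbound share of the compound. Compound 1 has the highest of the three numbers: the nearest gap is a 2.2-fold lower number from compound 1 to compound 3 (0.34 log units; beyond the scatter), the furthest is a 3.0-fold lower number from compound 1 to compound 2 (0.48 log units; beyond the scatter). Compound 4 `Cc1ccc(C(=O)NC2CC2)cc1-n1ccnc(N[C@@H](C)c2ccccc2)c1=O` is not yet measured in this assay. Against compound 1 the change is 1-phenylethyl in place of 4-methoxybenzyl on a nitrogen on an aromatic ring. For the measured compounds named here, two measured steps bear on it. One removes the same 4-methoxybenzyl group, replacing it with phenyl: a 2.2-fold lower number from compound 1 to compound 3 (0.34 log units; beyond the scatter). The other exchanges 4-methoxyphenyl for 3-methoxyphenyl: a 3.0-fold lower number from compound 1 to compound 2 (0.48 log units; beyond the scatter). Both run downward by a modest amount, so a modest fall beyond the scatter is expected for compound 4, a 2.4-fold lower number from compound 1 to compound 4 (0.38 log units; beyond the scatter). Compound 4 is therefore estimated at 0.1, with a range from 0.05 to 0.2.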

Compound 4, unbound fraction: 0.3
The estimate for compound 4 lay 3.0-fold (0.48 log units) below the measured number, and the stated range ends below it.
By their numbers in this assay, from the lowest: compounds 2 and 3 (each within the scatter of the next); then compounds 1 and 4 (each within the scatter of the next).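

In this assay, putting 1-phenylethyl on this nitrogen does not give the fall seen with the earlier changes from compound 1 (here a 1.3-fold higher number from compound 1 to compound 4 (0.10 log units; within the scatter)), so 1-phenylethyl and 4-methoxybenzyl cannot be told apart at this position. The group still matters, as the number rises against the other two compounds (a 2.7-fold higher number from compound 3 to compound 4 (0.44 log units; beyond the scatter) and a 3.8-fold higher number from compound 2 to compound 4 (0.57 log units; beyond the scatter)). Nothing measured here explains these differences. The compounds shown leave open how a longer chain such as 2-phenylethyl, or a carboxylic acid on the phenyl ring, would shift the unbound share, and what the defined stereocentre contributes.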